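Replacing the 3-methoxyphenyl group of compound 1

The source may hold more compounds than are shown below. What is called first, only, known or untested is meant among the compounds shown, and "the series" means these compounds.

Compound 1 `COc1cccc(NC(=O)C2CCN(C/C=C/c3ccccc3)CC2)c1`: 50500 nM
Compound 2 `O=C(Nc1cccc(C(F)(F)F)c1)C1CCN(C/C=C/c2ccccc2)CC1`: 15600 nM
Compound 3 `CN1CCN(c2ccc(NC(=O)C3CCN(C/C=C/c4ccccc4)CC3)cc2)CC1`: 19900 nM

In a functional assay on A549 cells (Homo sapiens) for inhibition, read by MTT assay, with a stated time of 72 h (on this read-out lower numbers stand for stronger inhibition and higher numbers for weaker inhibition), compound 1 has the highest number of the three, and compounds 2 and 3 both lie lower, beyond the scatter. Compound 4 `O=C(Nc1ccccn1)C1CCN(C/C=C/c2ccccc2)CC1` keeps the core of compound 1 and carries pyridin-2-yl in place of 3-methoxyphenyl on an amide-type nitrogen. Among the compounds with values here, only one measured step bears on this, and only loosely: trifluoromethyl in place of methoxy on an aromatic carbon gave a 3.2-fold lower number from compound 1 to compound 2 (0.51 log units; beyond the scatter), a modest change. Within the data shown here, no measured compound carries pyridin-2-yl. A small move toward a lower number in this assay is therefore expected, possibly none beyond the scatter. The expected step is a 1.7-fold lower number from compound 1 to compound 4 (0.23 log units; within the scatter). Compound 4 is estimated at 30000 nM, with an expected range from 12000 nM to 80000 nM.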

Compound 4, half-maximal inhibitory concentration: 89300 nM
The estimate for compound 4 lay 3.0-fold (0.47 log units) below the measured number; the measured number lies above the stated range.
By their numbers in this assay, from the lowest: compounds 2 and 3 (each within the scatter of the next); then compounds 1 and 4 (each within the scatter of the next).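

In this assay, pyridin-2-yl in place of 3-methoxyphenyl on the amide-type nitrogen gives a 1.8-fold higher number from compound 1 to compound 4 (0.25 log units; within the scatter), whereas the earlier change on the aromatic carbon gave a 3.2-fold lower number from compound 1 to compound 2 (0.51 log units; beyond the scatter). So, at this place, exchanging the whole ring for one with a hetero atom and fewer heavy atoms does not move the number beyond the scatter. No measurement available here explains this result. The compounds shown leave open whether an amine or a carboxylic acid carried on the pyridin-2-yl ring would shift the number beyond the scatter.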